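This account rests on a few compounds, and the source may have more. Where it says the series, first, only, none or still open, it means among the compounds named here.

In an ADME assay on MT4 cells (Homo sapiens) for cytotoxicity, read by MTT assay, with a stated time of 5 days (on this read-out higher numbers stand for lower toxicity in this test and lower numbers for higher toxicity in this test), compound 1 `COc1cc2nc(SCC(=O)Nc3ccc(S(N)(=O)=O)cc3)nc(Nc3c(Cl)cc(/C=C/C#N)cc3Cl)c2cc1OC` gives 116000 nM. Compound 2 `COc1cc2nc(SCC(=O)Nc3cccc(Cl)c3)nc(Nc3c(Cl)cc(/C=C/C#N)cc3Cl)c2cc1OC` is reported only as a limit, > 208000 nM, and no exact number is available for it. Its position on the scale is therefore (the limit of > 208000 nM in this assay, at which 1 of the 2 values shown sits).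

Compound 3 `COc1cc2nc(SCC(=O)Nc3ccc(C(F)(F)F)cc3)nc(Nc3c(Cl)cc(/C=C/C#N)cc3Cl)c2cc1OC` departs from compound 2 at a single place on the shared core: 4-(trifluoromethyl)phenyl in place of 3-chlorophenyl on an amide-type nitrogen. In words, this puts 4-(trifluoromethyl)phenyl in place of 3-chlorophenyl on an amide-type nitrogen.

Going by the values given here, only one measured step bears on this place, an at least 1.7-fold higher number from compound 1 to compound 2 (0.25 log units; that floor lies within the scatter). That step exchanges a different pair of groups, and it gives only a floor rather than a true size, so it offers weak guidance for the new change. No step beyond the scatter is therefore expected in this assay, and neither direction is favoured. The expected change is an at least 1.0-fold lower number from compound 2 to compound 3 (0.01 log units; that floor lies within the scatter), and this is an estimate only. It may well be that only a limit is reported again. For compound 3 the estimated value is 200000 nM, with an expected range from 90000 nM to 350000 nM.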

Compound 3, half-maximal cytotoxic concentration: > 197000 nM
Compound 3: only a limit was reported; the forecaster's own chance of this, stated with the estimate: 60%; the middle value lies beyond the limit too.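

In this assay, compound 3 is reported only as a limit, as compound 2 is, so a second aryl group on the amide-type nitrogen, 4-(trifluoromethyl)phenyl, again yields no exact number: the limit of > 197000 nM in this assay, at which 1 of the 3 values shown sits.

With limits on both sides, the step between compound 2 and compound 3 cannot be read, and the two groups cannot be placed in any order. Trifluoromethyl in place of sulfamoyl on an aromatic carbon gives an at least 1.6-fold higher number from compound 1 to compound 3 (0.23 log units; that floor lies within the scatter), and because this is only a floor within the scatter, it does not establish an order between the two compounds, so the new result adds a second limit at this position rather than a measured size of change.

The compounds shown leave open how far compound 2 and compound 3 lie beyond their limits, and whether any group at this position would give an exact value in this assay other than the one seen with sulfamoyl. As far as these compounds go, an amine or a carboxylic acid on this phenyl ring also remains open, as does a longer alkyl chain in place of the ring on the amide-type nitrogen.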